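The source may report more compounds than this note shows. Statements on the series, on what has been measured and on what is new or still open speak of the compounds shown alone.

Measured so far in a functional assay on HepG2 cells (Homo sapiens) for cytotoxicity, read by MTT assay, with a stated time of 48 h; on this read-out lower numbers stand for stronger inhibition and higher numbers for weaker inhibition:
compound 1 `O=C(CSc1nnc(-c2ccncc2)o1)N/N=C/c1ccccc1` — 17300 nM
compound 2 `O=C(CSc1nnc(-c2ccncc2)o1)N/N=C/c1ccc(O)cc1` — 5510 nM
compound 3 `COc1cccc(/C=N/NC(=O)CSc2nnc(-c3ccncc3)o2)c1` — 9170 nM

Among these three, compound 1 has the highest number. Its nearest neighbour is compound 3, reached by a 1.9-fold lower number from compound 1 to compound 3 (0.28 log units; within the scatter), a step within the scatter; the furthest is compound 2, reached by a 3.1-fold lower number from compound 1 to compound 2 (0.50 log units; beyond the scatter), a modest step beyond the scatter. Compound 4 `O=C(CSc1nnc(-c2ccncc2)o1)N/N=C/c1ccccc1F` differs from compound 1 in one place: fluoro in place of hydrogen on an aromatic carbon. The two steps that bear on it, both substitutions on the same ring of compound 1, were small: one within the scatter, one modest. A fluoro group carries neither of the counted donor or acceptor features of those substituents, so the step in this assay is expected to be small, probably within the scatter, with a slight lean toward a lower number. Compound 4 is therefore estimated at 13000 nM, range 5500 nM to 31000 nM, corresponding to an expected 1.3-fold lower number from compound 1 to compound 4 (0.12 log units; within the scatter).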

Compound 4, half-maximal inhibitory concentration: 16000 nM
The estimate for compound 4 lay 1.2-fold (0.09 log units) below the measured number, within the range that was stated.
By their numbers in this assay, from the lowest: compounds 2, 3, 4 and 1 (each within the scatter of the next, the first and the last beyond it).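

In this assay, for the compounds shown here, fluoro in place of hydrogen on an aromatic carbon, ortho to a large group, gave no step that can be told from the scatter (a 1.1-fold lower number from compound 1 to compound 4 (0.03 log units; within the scatter)). Compound 4 also stays within the scatter of the methoxy compound (a 1.7-fold higher number from compound 3 to compound 4 (0.24 log units; within the scatter)) but not of the hydroxy compound (a 2.9-fold higher number from compound 2 to compound 4 (0.46 log units; beyond the scatter)), so this position tolerates fluoro without a readable gain or loss. Nothing available explains this result.

On these data alone, whether an amine or a carboxylic acid at this position would move the number beyond the scatter remains open. So does whether 4-fluorophenyl would read like 2-fluorophenyl.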